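This account rests on a few compounds, and the source may have more. Where it says the series, first, only, none or still open, it means among the compounds named here.

In a functional assay on A498 cells (Homo sapiens) for cytotoxicity, read by sulforhodamine B assay, with a stated time of 48 h, tested at 100 uM (on this read-out lower numbers stand for a stronger effect and higher numbers for a weaker effect at the one concentration tested), compound 1 `COc1cc(-c2cc(/C=C/C(=O)c3ccc(N)cc3)[nH]n2)cc(OC)c1OC` gives -96%, the second highest of the three numbers. Compound 3 `COc1ccc(-c2cc(/C=C/C(=O)c3ccc(N)cc3)[nH]n2)cc1OC` gives -98%, and compound 2 `COc1ccc(-c2cc(/C=C/C(=O)c3ccc(OC)c(OC)c3)[nH]n2)cc1` gives -90%; all three lie within the scatter of one another. For the measured compounds named here, the only step between measured compounds that differ in one place, a number 2 percentage points lower from compound 1 to compound 3 (within the scatter), was within the scatter. Compound 4 `COc1ccc(C(=O)/C=C/c2cc(-c3cc(OC)c(OC)c(OC)c3)n[nH]2)cc1` differs from compound 1 by methoxy in place of amino on an aromatic carbon. Going by the values given here, no measured pair shows exactly this change, so only the closeness of the three numbers guides the expectation: no step beyond the scatter in this assay. Compound 4 is therefore expected to give -93%, between -100% and -80%. The step of a number 3 percentage points higher from compound 1 to compound 4 (within the scatter) is expected to stay within the scatter.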

Compound 4, a percentage reported as activity, at one concentration (the size of the read-out at that concentration, not a potency): -34%
Estimate against measurement, compound 4: 59 percentage points below; the measured number lies above the stated range.
By their numbers in this assay, from the lowest: compounds 3, 1 and 2 (each within the scatter of the next); then compound 4.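

In this assay, replacing 4-aminophenyl with 4-methoxyphenyl gives a number 62 percentage points higher from compound 1 to compound 4 (beyond the scatter). For the compounds shown here, the only earlier one-place step, a number 2 percentage points lower from compound 1 to compound 3 (within the scatter), lay elsewhere on the core, so this is the first sign of a position where one exchange changes the read-out strongly. Nothing measured here accounts for the step. As far as these compounds go, whether it follows from the loss of the amino group or from the arrival of the methoxy group stays open. A hydroxyl or a methylamino group at this place would help separate the two.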